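Compound 4: methoxy to hydrogen on the aromatic carbon

The compounds below may be only part of what the source reports. "The series", "measured", "known", "first", "only" and "open" are said of these compounds alone.

Compound 1 `COc1ccc(Nc2cc(-c3ccccc3)oc(=O)c2)cc1` gives 0.12 uM in a functional assay on DU-145 cells (Homo sapiens) for cytotoxicity, read by MTT assay, with a stated time of 72 h (a higher number here means that more compound is needed for the effect, a lower number that less compound is needed), and stands second highest of the three measured values. Compound 3 `COc1ccc(Nc2cc(/C=C/c3ccccc3)oc(=O)c2)cc1` gives 0.11 uM in this assay, and a 1.1-fold lower number from compound 1 to compound 3 (0.04 log units; within the scatter). Compound 2 `COc1ccc(Nc2cc(C3CCCC3)oc(=O)c2)cc1` gives 5.42 uM in this assay, and a 45-fold higher number from compound 1 to compound 2 (1.65 log units; beyond the scatter). Both measured steps alter a different group of compound 1 and leave the methoxy unchanged. Compound 4 `O=c1cc(Nc2ccccc2)cc(-c2ccccc2)o1` differs from compound 1 by hydrogen in place of methoxy on an aromatic carbon. Among the compounds with values here, no measured step bears on this change, so the expectation rests on compound 1 alone: a step within the scatter is expected, with no direction beyond it. Compound 4 is estimated at 0.2 uM (range 0.06 uM to 0.7 uM), which means a 1.7-fold higher number from compound 1 to compound 4 (0.22 log units; within the scatter) is expected.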

Compound 4, concentration for half-maximal effect: 0.098 uM
Estimate against measurement, compound 4: 2.0-fold (0.31 log units) above; the range from low to high includes it.
By their numbers in this assay, from the lowest: compounds 4, 3 and 1 (each within the scatter of the next); then compound 2.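

Hydrogen in place of methoxy on the aromatic carbon para to a large group gives a 1.2-fold lower number from compound 1 to compound 4 (0.09 log units; within the scatter) in this assay, the first reading at this position, since compounds 2 and 3 vary only the other group. The methoxy is therefore not required for the value of compound 1 on this core. No evidence on the cause of this result is available.

Open, going by these compounds, is whether an amine or a carboxylic acid at this position would fit the same picture. Also open, on these data alone, is whether hydrogen here would give a similar step with the cyclopentyl of compound 2.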